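This account rests on a few compounds, and the source may have more. Where it says the series, first, only, none or still open, it means among the compounds named here.

Compound 1 `CC(C)(CN)CCN(C[C@H]1Cc2ccccc2CN1)[C@H]1CCCc2cccnc21`: 69 nM
Compound 2 `CC1(C)CCC(NC/C=C/CN(C[C@H]2Cc3ccccc3CN2)[C@H]2CCCc3cccnc32)CC1`: 64.6 nM

Of the compounds shown here, two have so far been measured in a functional assay on cells for antagonist activity at C-X-C chemokine receptor type 4 (Homo sapiens), read by fluorescence and calcium flux, with stated times of 25 min and 90 s; a lower number here means a stronger inhibitor, a higher number a weaker inhibitor. Compound 1 gives 69 nM there, and compound 2 gives 64.6 nM. These two numbers lie within the scatter of each other, so compound 2 stands level with compound 1 rather than apart from it. Compound 3 `C(=C/CN(C[C@H]1Cc2ccccc2CN1)[C@H]1CCCc2cccnc21)\CNCc1ccccn1` has not yet been measured. It differs from compound 2 in a single place: (pyridin-2-yl)methyl in place of 4,4-dimethylcyclohexyl on an amine nitrogen, in words, (pyridin-2-yl)methyl in place of 4,4-dimethylcyclohexyl on an amine nitrogen. Among the measured compounds shown here, no measured pair shows a change of this kind, so no step can be read off from data. Only a small shift is expected in this assay, and the estimated step is a 1.3-fold higher number from compound 2 to compound 3 (0.12 log units; within the scatter), which does not go beyond the scatter. Compound 3 is therefore expected to give about 85 nM, in a range from 25 nM to 300 nM.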

Compound 3, half-maximal inhibitory concentration in the C-X-C chemokine receptor type 4 assay: 58.3 nM
The estimate for compound 3 lay 1.5-fold (0.16 log units) above the measured number; measured number inside the range.
By their numbers in the C-X-C chemokine receptor type 4 assay, from the lowest: compounds 3, 2 and 1 (each within the scatter of the next).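

In the C-X-C chemokine receptor type 4 assay, putting (pyridin-2-yl)methyl in place of 4,4-dimethylcyclohexyl on an amine nitrogen gives a 1.1-fold lower number from compound 2 to compound 3 (0.04 log units; within the scatter), so at this place one six-membered aromatic ring with 1 hetero atom and one six-membered non-aromatic ring of carbon only cannot be told apart in this assay. The wider difference, on a saturated chain carbon bound to an amine nitrogen, gives a 1.2-fold lower number from compound 1 to compound 3 (0.07 log units; within the scatter) and likewise stays within the scatter, so all three compounds stand level despite their different groups at this place. Nothing at hand gives a reason for this levelness.

In a physicochemical assay for permeability, using PAMPA, with a stated time of 4 h, at pH 7.4, tested at 100 uM (a lower number here means that the compound crosses the layer more slowly, a higher number that the compound crosses the layer faster), compound 3 gives 50 nm/s, while for compound 2 the entry reads "not determined" (no result reported), so no step can be read there. On these data alone, whether a carboxylic acid or an amide on that amine nitrogen would also leave the number in the C-X-C chemokine receptor type 4 assay level remains open.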